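Three Inactive Sulfonyl Analogues and a Trifluorophenyl Newcomer

The source may hold more compounds than are shown below. What is called first, only, known or untested is meant among the compounds shown, and "the series" means these compounds.

Compound 1 has the structure `COc1ccc(-c2cc(=O)c3c(OC)cc(OC)cc3n2S(=O)(=O)c2cccc([N+](=O)[O-])c2)cc1`; in a functional assay on HepG2 cells (Homo sapiens) for antiproliferative activity, with a stated time of 72 h (on this read-out higher numbers stand for an effect only at larger amounts of compound and lower numbers for an effect already at smaller amounts), compound 1 gives > 39600 nM, which is a limit of the assay and not a number.
Compound 2 has the structure `COc1ccc(-c2cc(=O)c3c(OC)cc(OC)cc3n2S(=O)(=O)c2ccc(C#N)cc2)cc1`; in this assay compound 2 gives > 17200 nM, again a limit.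
Compound 3 has the structure `COc1ccc(-c2cc(=O)c3c(OC)cc(OC)cc3n2S(=O)(=O)c2ccc(F)cc2)cc1`; in this assay compound 3 gives > 65500 nM, also a limit.

Compound 3 thus stands where the other two stand: at a limit, with no number to compare. The steps a step that the two limits leave unreadable from compound 1 to compound 2, a step that the two limits leave unreadable from compound 1 to compound 3 and a step that the two limits leave unreadable from compound 2 to compound 3 all join two limits, so their size cannot be read; the lines (the limit of > 17200 nM in this assay, at which 1 of the 3 values shown sits), the limit of > 39600 nM in this assay, at which 1 of the 3 values shown sits, and the limit of > 65500 nM in this assay, at which 1 of the 3 values shown sits, show that every value here is a limit.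

Compound 4 has the structure `COc1ccc(-c2cc(=O)c3c(OC)cc(OC)cc3n2S(=O)(=O)c2cc(F)c(F)c(F)c2)cc1`. The change is 3,4,5-trifluorophenyl in place of 4-fluorophenyl on a sulfonyl sulfur. The steps from compound 1 to compound 3 and from compound 2 to compound 3 concern the same sulfonyl-bound phenyl group, but neither gives a readable size. The step of an at least 1.0-fold lower number from compound 3 to compound 4 (0.03 log units; that floor lies within the scatter) is therefore only an expectation of our own, and it is expected to stay unreadable. Compound 4 is accordingly expected to give about 60000 nM in this assay, most likely reported as a limit, within a range from 20000 nM to 200000 nM.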

Compound 4, half-maximal effective concentration: > 65500 nM
Compound 4: no number, only a limit; the forecaster's own chance of this, stated with the estimate: 80%; middle value at least 1.0-fold (0.03 log units) from the limit.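

Compound 4, like compound 1, compound 2 and compound 3, gives only a limit of the assay and not a number, so the steps joining compound 4 to each of them cannot be read; the limit it shares with compound 3 is this: the limit of > 65500 nM in this assay, at which 2 of the 4 values shown sit.

The compounds shown leave open whether any of these sulfonyl-bound phenyl groups on the shared core gives a measurable effect in this assay.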